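This account rests on a few compounds, and the source may have more. Where it says the series, first, only, none or still open, it means among the compounds named here.

Of the compounds shown here, two built on one shared core have so far been measured in a functional assay on HEK293 cells for agonist activity at G-protein coupled receptor 39 (Homo sapiens), read by scintillation proximity assay and inositol phosphate accumulation, with a stated time of 75 min, in the presence of a further agent that is not named here; on this read-out lower numbers stand for an effect already at smaller amounts and higher numbers for an effect only at larger amounts of compound. Compound 1 `Cc1nn(-c2ncnc3nc[nH]c23)c2c1C(OCc1cc(F)cc3c1OCOC3)CC(=O)N2` gives 1.5 nM in this assay, and compound 2 `Cc1nn(-c2ncnc3nc[nH]c23)c2c1C(OCCn1cccn1)CC(=O)N2` gives 16 nM in this assay. Going by the values given here, compound 2 therefore stands with the higher of the two numbers, its only neighbour being compound 1, and the single measured step between them, an 11-fold higher number from compound 1 to compound 2 (1.03 log units; beyond the scatter), is large and beyond the scatter.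

The account now turns to compound 3 `Cc1nn(-c2ncnc3nc[nH]c23)c2c1C(OCc1ccc(F)cc1)CC(=O)N2`, which has not yet been measured in this assay. It differs from compound 2 in one place: 4-fluorophenyl in place of (1H-pyrazol-1-yl)methyl on a saturated chain carbon bound to an oxygen on a saturated carbon. Among the compounds with values here, the only measured step that bears on this change is an 11-fold higher number from compound 1 to compound 2 (1.03 log units; beyond the scatter), where a group holding a six-membered aromatic ring of carbon only, reached through an oxygen on a saturated carbon, gave way to a group holding a five-membered aromatic ring with 2 hetero atoms, and the number rose sharply. Compound 3 brings a six-membered aromatic ring of carbon only back to that place, so a move in the opposite direction is expected. The step of a 5.3-fold lower number from compound 2 to compound 3 (0.73 log units; beyond the scatter) is the expected outcome. Compound 3 is accordingly estimated at 3 nM, within a range of 1 nM to 10 nM.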

Compound 3, half-maximal effective concentration: 1 nM
For compound 3 the middle estimate is 3.0-fold (0.48 log units) above the measured one; the measured number falls inside the stated range.
By their numbers in this assay, from the lowest: compounds 3 and 1 (each within the scatter of the next); then compound 2.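

In this assay, 4-fluorophenyl in place of (1H-pyrazol-1-yl)methyl on a saturated chain carbon bound to an oxygen on a saturated carbon gives a 16-fold lower number from compound 2 to compound 3 (1.20 log units; beyond the scatter), so this place responds strongly to a second, simpler exchange of groups as well. The other new step, a 1.5-fold lower number from compound 1 to compound 3 (0.18 log units; within the scatter), lies within the scatter: the group of compound 3, with one six-membered aromatic ring of carbon only, cannot be told apart from the larger group of compound 1, which also carries a six-membered non-aromatic ring with 2 hetero atoms. That further ring is therefore not required for a number of this size, and all three compounds fit one reading: the two with an aromatic ring of carbon only sit together, while compound 2, with its five-membered aromatic ring, stands apart. Nothing shown here gives a reason for either step.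

The compounds shown leave open whether the fluorine of the 4-fluorobenzyl group contributes anything to these numbers. They also leave open how this place would respond to an amine or a carboxylic acid on the aromatic ring, or to a longer chain in place of 4-fluorobenzyl.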